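Removing the anilide ring from the cyanoacrylamide series

The source may report more compounds than this note shows. Statements on the series, on what has been measured and on what is new or still open speak of the compounds shown alone.

For the measured compounds named here, compound 1 `COc1ccc(NC(=O)/C(C#N)=C/c2cc(O)c(O)c([N+](=O)[O-])c2)cc1` gives the lowest of the three numbers measured so far, 29.2 ug/mL in a functional assay on KB cells (Homo sapiens) for antiproliferative activity, read by MTT assay; on this read-out higher numbers stand for weaker inhibition and lower numbers for stronger inhibition. Compound 3 `N#C/C(=C\c1cc(O)c(O)c([N+](=O)[O-])c1)C(=O)Nc1ccccc1Cl` gives 37.4 ug/mL, and the step of a 1.3-fold higher number from compound 1 to compound 3 (0.11 log units; within the scatter) stays within the scatter. Compound 2 `N#C/C(=C\c1cc(O)c(O)c([N+](=O)[O-])c1)C(=O)Nc1cccc(Cl)c1` gives 72.7 ug/mL, and the step of a 2.5-fold higher number from compound 1 to compound 2 (0.40 log units; beyond the scatter) lies beyond it. Compound 4 `N#C/C(=C\c1cc(O)c(O)c([N+](=O)[O-])c1)C(N)=O` differs from compound 1 by hydrogen in place of 4-methoxyphenyl on an amide-type nitrogen. Going by the values given here, no measured step removes the aryl group altogether; the two steps from compound 1 only exchange one aryl for another, and neither produced a lower number. On that basis compound 4 is expected to give a higher number than compound 1, with an estimated step of a 2.1-fold higher number from compound 1 to compound 4 (0.31 log units; beyond the scatter) whose size is uncertain. The estimate for compound 4 is 60 ug/mL, within a range of 20 ug/mL to 200 ug/mL.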

Compound 4, half-maximal inhibitory concentration: > 100 ug/mL
Compound 4 ended at the assay's limit; the forecaster's own chance of this, stated with the estimate: 15%; at least 1.6-fold (0.22 log units) between middle value and limit.
By their numbers in this assay, from the lowest: compounds 1, 3 and 2 (each within the scatter of the next, the first and the last beyond it). At a limit, above all of these: compound 4.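

In this assay compound 4 stands at a limit, not at a number: the limit of > 100 ug/mL in this assay, at which 1 of the 4 values shown sits.
Taking the aryl group off the amide-type nitrogen altogether, rather than exchanging it, gives an at least 3.4-fold higher number from compound 1 to compound 4 (0.53 log units; beyond the scatter) and also an at least 2.6-fold higher number from compound 3 to compound 4 (0.42 log units; beyond the scatter), so hydrogen here gives a higher number than either 4-methoxyphenyl or 2-chlorophenyl.
Against 3-chlorophenyl the comparison stays unresolved, with an at least 1.3-fold higher number from compound 2 to compound 4 (0.13 log units; that floor lies within the scatter).

As far as these compounds go, how far past the limit compound 4 lies remains unknown. From the compounds shown here alone, whether a methyl or benzyl group on this nitrogen would match the aryl amides also remains open.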